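The compounds below may be only part of what the source reports. "The series", "measured", "known", "first", "only" and "open" are said of these compounds alone.

Compound 1 `COC(=O)N1N=C(c2ccccc2)CC1c1ccccc1`: > 10000 nM (a limit of the assay)
Compound 2 `COC(=O)N1N=C(c2ccccc2)CC1c1ccc(OC)c(O)c1`: 9810 nM

For the measured compounds named here, in a functional assay on HepG2 cells (Homo sapiens) for antiproliferative activity, read by MTT assay, with a stated time of 48 h (a lower number here means a stronger inhibitor of growth, a higher number a weaker inhibitor of growth), compound 2 at 9810 nM holds the only actual number. Compound 3 `COC(=O)N1N=C(c2ccccc2)CC1c1ccc(OC)cc1` follows from compound 2 by hydrogen in place of hydroxy on an aromatic carbon, ortho to a methoxy group. No measured step sizes this change in this assay. Compound 1 also has no hydroxy, and its > 10000 nM is a limit. A small move towards weaker growth inhibition is therefore expected, near the scatter, and a limit is quite possible. The expected change is a 1.4-fold higher number from compound 2 to compound 3 (0.15 log units; within the scatter). For compound 3 the estimate is 14000 nM, with an expected range of 6000 nM to 30000 nM.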

Compound 3, concentration for 50% growth inhibition: 12000 nM
Estimate against measurement, compound 3: 1.2-fold (0.07 log units) above; the measured number falls inside the stated range.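

In this assay, hydrogen in place of hydroxy on the aromatic carbon ortho to a methoxy group gives a 1.2-fold higher number from compound 2 to compound 3 (0.09 log units; within the scatter). For the compounds shown here, this is the first measured step at this position, and hydroxy and hydrogen cannot be told apart there. Compound 1 stands at a limit, not a number, and its step to compound 3 cannot be read: the limit of > 10000 nM in this assay, at which 1 of the 3 values shown sits.

On these data alone, what the methoxy group itself contributes therefore stays open. Also open, as far as these compounds go, is whether an amine, a carboxylic acid or a longer alkoxy chain at the hydroxy position would separate from hydrogen.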